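A few compounds are considered here, and "the series" means these few. Any claim that something is new, unique, unknown or untested is made for them only; others in the source may bear on it.

Measured in a functional assay on NCI-H460 cells (Homo sapiens) for cytotoxicity, read by MTT assay, with a stated time of 68 h; on this read-out lower numbers stand for stronger inhibition and higher numbers for weaker inhibition:

Compound 1 `O=C(Nc1cccc(-c2ccccc2C(F)(F)F)c1)C(Cl)Cl`: 7550 nM
Compound 2 `O=C(Nc1cccc(-c2ccccn2)c1)C(Cl)Cl`: > 50000 nM
Compound 3 `O=C(Nc1cccc(-c2ccc(-c3ccccc3)cc2)c1)C(Cl)Cl`: 10900 nM

Only two of these results are numbers. Compound 1 at 7550 nM and compound 3 at 10900 nM lie within the scatter of each other. Compound 2 stands apart, with > 50000 nM being a limit of the assay and not a number.

The next compound departs from compound 1 in one place. Compound 4 `O=C(Nc1cccc(-c2ccccc2F)c1)C(Cl)Cl` carries fluoro in place of trifluoromethyl on an aromatic carbon, ortho to a large group (fluoro in place of trifluoromethyl on an aromatic carbon). For the measured compounds named here, no measured pair isolates this kind of change, so the data give no direct size for it. In this assay, a step of about the size of the scatter is expected, towards a higher number and thus weaker inhibition. That modest expectation rests on compound 3, whose 10900 nM stays close to the number for compound 1. Compound 2 goes against any reading that changes in this part of the molecule are harmless, so the expected range is kept wide on the upper side.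

The expected move is a 1.9-fold higher number from compound 1 to compound 4 (0.27 log units; within the scatter). For compound 4 the estimated value is 14000 nM. The expected range for compound 4 runs from 6000 nM to 38000 nM.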

Compound 4, half-maximal inhibitory concentration: 26800 nM
Compound 4: the middle estimate sits 1.9-fold (0.28 log units) below what was measured; the measured number falls inside the stated range.
By their numbers in this assay, from the lowest: compounds 1 and 3 (each within the scatter of the next); then compound 4. At a limit, above all of these: compound 2.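

In this assay, the exchange at this aromatic carbon gives the first direct size for this kind of change, with fluoro in place of trifluoromethyl: a 3.5-fold higher number from compound 1 to compound 4 (0.55 log units; beyond the scatter), a step that lies beyond the scatter. The earlier compounds shown here could not show this, as no two of them formed a pair differing in one place; here, with the rest of the molecule held constant, the group on this carbon alone separates the two numbers, so the position is not indifferent to which of these two groups it carries. Nothing in the data shown accounts for the size or direction of this step, which comes from a single pair and sets no general pattern.

From the compounds shown here alone, it remains open whether a chloro, a methoxy or an amine on the same aromatic carbon would give a number closer to that of compound 1 or to that of compound 4. Going by these compounds, it is equally open whether fluoro in place of trifluoromethyl would give a step of similar size and direction in a molecule with a different core, or with the group placed elsewhere on the same ring.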